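Clearance of compound 4: an amino-linked pyrazole

The source may report more compounds than this note shows. Statements on the series, on what has been measured and on what is new or still open speak of the compounds shown alone.

Measured in an ADME assay on microsomes from liver (Homo sapiens) for metabolic stability, read by LC-MS, using NADPH, with stated times of 5 min and 30 min, tested at 1 uM; a lower number here means slower removal, a higher number faster removal of the compound:
compound 1 `Cc1nc(CO)ccc1-c1cnc(NCc2c(F)ccc3c2CCO3)c2cn[nH]c(=O)c12`: 11 mL.min-1.g-1
compound 2 `Cc1nc(CN(C)C)ccc1-c1cnc(NCc2c(F)ccc3c2CCO3)c2cn[nH]c(=O)c12`: 13 mL.min-1.g-1
compound 3 `Cc1cc(-c2cnc(NCc3c(F)ccc4c3CCO4)c3cn[nH]c(=O)c23)n(C)n1`: 24 mL.min-1.g-1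

Compound 3 gives the highest of the three numbers, 24 mL.min-1.g-1. Compound 4 `CN(c1ccn(C)n1)c1cnc(NCc2c(F)ccc3c2CCO3)c2cn[nH]c(=O)c12` carries methyl(1-methyl-1H-pyrazol-3-yl)amino in place of 1,3-dimethyl-1H-pyrazol-5-yl on an aromatic carbon. Two measured steps change the group on this carbon: a 2.2-fold higher number from compound 1 to compound 3 (0.34 log units; beyond the scatter) and a 1.8-fold higher number from compound 2 to compound 3 (0.27 log units; within the scatter). Neither brings in an amino-linked group, so they guide the size of the step only loosely. Both are small, so no step beyond the scatter is expected in this assay, and the expected step is a 1.1-fold higher number from compound 3 to compound 4 (0.03 log units; within the scatter). For compound 4 the estimated value is 26 mL.min-1.g-1, with an expected range of 12 mL.min-1.g-1 to 55 mL.min-1.g-1.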

Compound 4, intrinsic clearance in microsomes: 62 mL.min-1.g-1
Compound 4: the middle estimate sits 2.4-fold (0.38 log units) below what was measured; the measured number lies above the stated range.
By their numbers in this assay, from the lowest: compounds 1, 2 and 3 (each within the scatter of the next, the first and the last beyond it); then compound 4.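

In this assay, every step to methyl(1-methyl-1H-pyrazol-3-yl)amino lies beyond the scatter: a 2.6-fold higher number from compound 3 to compound 4 (0.41 log units; beyond the scatter), a 4.8-fold higher number from compound 2 to compound 4 (0.68 log units; beyond the scatter) and a 5.6-fold higher number from compound 1 to compound 4 (0.75 log units; beyond the scatter). This aromatic carbon is therefore not indifferent to the group it carries, and compound 4 has the highest number of the four compounds. No measurement bearing on the reason for this rise is available.

Compound 4 changes the ring and the link together, leaving their separate contributions open. A plain amino link without the methyl, bearing the same 1-methyl-1H-pyrazol-3-yl ring, would test the methyl alone.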